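Cytotoxicity notes: hydroxymethyl for methoxymethyl on the aniline ring

The compounds below may be only part of what the source reports. "The series", "measured", "known", "first", "only" and "open" are said of these compounds alone.

The series shares one core; the three measured compounds differ only in the group on an aromatic carbon of the aniline ring. Compound 1 `N#Cc1ccc(Nc2ncc(Cc3c(F)cccc3F)o2)cc1` carries a cyano group and in an ADME assay on MT2 cells (Homo sapiens) for cytotoxicity, read by MTT assay (on this read-out higher numbers stand for lower toxicity in this test and lower numbers for higher toxicity in this test), compound 1 gives 7400 nM. Compound 2 `Fc1cccc(F)c1Cc1cnc(Nc2ccc(Oc3cccnc3)cc2)o1` carries a (pyridin-3-yl)oxy group, and in this assay compound 2 gives 22000 nM. Compound 3 `COCc1ccc(Nc2ncc(Cc3c(F)cccc3F)o2)cc1` carries a methoxymethyl group, and in this assay compound 3 gives 32000 nM, the highest of the three numbers: one step is a 1.5-fold higher number from compound 2 to compound 3 (0.16 log units; within the scatter), within the scatter, while another is a 4.3-fold higher number from compound 1 to compound 3 (0.64 log units; beyond the scatter), beyond the scatter, as is a 3.0-fold higher number from compound 1 to compound 2 (0.47 log units; beyond the scatter).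

Compound 4 `OCc1ccc(Nc2ncc(Cc3c(F)cccc3F)o2)cc1` differs from compound 3 by hydrogen in place of methyl on an oxygen on a saturated carbon. Among the compounds with values here, no measured step removes a methyl from an oxygen; the steps that touch the methoxymethyl group, from compound 1 and from compound 2, swap the whole substituent rather than trim it, and the step from compound 2 is within the scatter. With nothing in the data to drive a change, the step in this assay is expected to stay within the scatter, a 1.1-fold lower number from compound 3 to compound 4 (0.03 log units; within the scatter). Compound 4 is therefore estimated at 30000 nM, in the range 12000 nM to 75000 nM.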

Compound 4, half-maximal cytotoxic concentration: > 100000 nM
Compound 4: no number, only a limit; the forecaster's own chance of this, stated with the estimate: 15%; middle value at least 3.3-fold (0.52 log units) from the limit.
By their numbers in this assay, from the lowest: compound 1; then compounds 2 and 3 (each within the scatter of the next). At a limit, above all of these: compound 4.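

In this assay compound 4 stands at a limit of the assay and not at a number: the limit of > 100000 nM in this assay, at which 1 of the 4 values shown sits. Hydrogen in place of methyl on an oxygen on a saturated carbon gives an at least 3.1-fold higher number from compound 3 to compound 4 (0.49 log units; beyond the scatter), so a change of 1 heavy atom at this position moves the read-out beyond the scatter, something the earlier steps could not show, as they swapped the whole substituent and one of them stayed within the scatter. Hydroxymethyl on an aromatic carbon also separates from the two other groups, with an at least 4.5-fold higher number from compound 2 to compound 4 (0.65 log units; beyond the scatter) and an at least 13-fold higher number from compound 1 to compound 4 (1.13 log units; beyond the scatter), which makes compound 4 the least toxic of the four compounds in this test, with all its steps beyond the scatter.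

As far as these compounds go, how far compound 4 lies past its limit stays open, so all three steps are known from one side only. Also open, from the compounds shown here alone, is whether an aminomethyl group, a carboxylic acid or a longer chain such as 2-hydroxyethyl in place of hydroxymethyl on the same aromatic carbon would keep the read-out at this limit or bring it back towards compound 3.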